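From Butyl Amide to Dibutyl Amide

The source may hold more compounds than are shown below. What is called first, only, known or untested is meant among the compounds shown, and "the series" means these compounds.

Measured compounds:
- compound 1 `CCNC(=O)/C=C/c1c(/C=C/c2ccc(OC)cc2)cc(OC)cc1OC`: 7060 nM
- compound 2 `CCCCNC(=O)/C=C/c1c(/C=C/c2ccc(OC)cc2)cc(OC)cc1OC`: 1330 nM
- compound 3 `COc1ccc(/C=C/c2cc(OC)cc(OC)c2/C=C/C(=O)Nc2cc(OC)c(OC)c(OC)c2)cc1`: 7010 nM

In a functional assay on MCF7 cells (Homo sapiens) for inhibition, read by MTT assay, with a stated time of 48 h (a higher number here means a weaker inhibitor, a lower number a stronger inhibitor), compound 2 gives the lowest number of the three, 1330 nM, and it stands apart from both others by more than the scatter. Compound 4 `CCCCN(CCCC)C(=O)/C=C/c1c(/C=C/c2ccc(OC)cc2)cc(OC)cc1OC` has not yet been measured. It differs from compound 2 by butyl in place of hydrogen on an amide-type nitrogen, which is butyl in place of hydrogen on an amide-type nitrogen, turning butylcarbamoyl into dibutylcarbamoyl.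

Going by the values given here, no measured step replaces the amide hydrogen, so the evidence is indirect. Lengthening the chain gave a 5.3-fold lower number from compound 1 to compound 2 (0.72 log units; beyond the scatter), a modest step. Exchanging butyl for 3,4,5-trimethoxyphenyl gave a 5.3-fold higher number from compound 2 to compound 3 (0.72 log units; beyond the scatter), equally modest, while a 1.0-fold lower number from compound 1 to compound 3 (0.00 log units; within the scatter) stayed within the scatter. These steps fix no firm direction, but with compound 2 at the low end, a modest rise in this assay is expected. The expected change is a 1.9-fold higher number from compound 2 to compound 4 (0.27 log units; within the scatter). The estimated value for compound 4 is 2500 nM, with an expected range from 800 nM to 8000 nM.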

Compound 4, half-maximal inhibitory concentration: 3990 nM
Compound 4: the middle estimate sits 1.6-fold (0.20 log units) below what was measured, within the range that was stated.
By their numbers in this assay, from the lowest: compound 2; then compounds 4, 3 and 1 (each within the scatter of the next).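

In this assay, going by these compounds alone, this is the first look at the amide hydrogen itself: butyl in its place, turning butylcarbamoyl into dibutylcarbamoyl, gives (a 3.0-fold higher number from compound 2 to compound 4 (0.48 log units; beyond the scatter)), so the gain seen along the chain (a 5.3-fold lower number from compound 1 to compound 2 (0.72 log units; beyond the scatter)) does not carry over to a second butyl on the amide-type nitrogen. The whole change of dibutylamino in place of ethylamino on the carbonyl carbon gives (a 1.8-fold lower number from compound 1 to compound 4 (0.25 log units; within the scatter)), so that pair cannot be separated in this assay. Nothing among the data shown accounts for the rise seen on adding the second butyl.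

As far as these compounds go, what remains open is whether a smaller group in the same place, such as methyl, would give a different result from butyl. From the compounds shown here alone, it is also open how a pentyl chain, or a piperidine in place of dibutylamino, would read here.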